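The source may report more compounds than this note shows. Statements on the series, on what has been measured and on what is new or still open speak of the compounds shown alone.

In a functional assay on HL-60 cells (Homo sapiens) for antiproliferative activity, read by XTT assay, with a stated time of 72 h (on this read-out higher numbers stand for weaker inhibition and lower numbers for stronger inhibition), compound 3 `C=C(C)CCC[C@]1(C)C2=CCC[C@](C)(C[C@@H](O)C3=CC(=O)OC3O)[C@H]2CC[C@H]1C` gives 3200 nM. Going by the values given here, that matches compound 2 `C=C(C)CCC[C@]1(C)C2=CCC[C@](C)(C[C@@H](OC(C)=O)C3=CC(=O)OC3O)[C@H]2CC[C@H]1C` at 3200 nM, and the two share the lowest number so far, while compound 1 `C=C(C)CC[C@]1(C)C2=CCC[C@](C)(C[C@H](O)c3ccoc3)[C@H]2CC[C@H]1C` sits clearly higher at 28700 nM.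

The next compound, compound 4 `C=C(C)CC[C@]1(C)C2=CCC[C@](C)(C[C@@H](O)C3=CC(=O)OC3O)[C@H]2CC[C@H]1C`, shortens the chain that ends in the alkene: 1-methylethenyl in place of 2-methylprop-2-en-1-yl on a saturated chain carbon, two bonds along the chain from a saturated ring carbon. In words, 1-methylethenyl stands in place of 2-methylprop-2-en-1-yl on a saturated chain carbon, two bonds along the chain from a saturated ring carbon.

Among the compounds with values here, no measured step tests this change directly. Within the data shown here, the only step available, no change at the digits printed from compound 2 to compound 3 (within the scatter), concerns an acetyl group elsewhere in the molecule, so it shows only that one edit left the number unchanged. Compound 1 at 28700 nM also carries the shorter chain, but it differs elsewhere too, so it cannot isolate the chain's contribution.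

With so little evidence, a step beyond the scatter is not expected, though a slight rise is possible: the estimated step is a 1.3-fold higher number from compound 3 to compound 4 (0.10 log units; within the scatter). For compound 4 the expected value is 4000 nM, with an estimated range from 1500 nM to 12000 nM.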

Compound 4, half-maximal inhibitory concentration: 3300 nM
Compound 4: the middle estimate sits 1.2-fold (0.08 log units) above what was measured; the measured number falls inside the stated range.
By their numbers in this assay, from the lowest: compounds 2, 3 and 4 (each within the scatter of the next); then compound 1.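

In this assay, replacing 2-methylprop-2-en-1-yl with 1-methylethenyl on a saturated chain carbon, two bonds along the chain from a saturated ring carbon, gives a 1.0-fold higher number from compound 3 to compound 4 (0.01 log units; within the scatter), so this pair shows that the shorter chain leaves the number in place. Going by these compounds alone, with that chain now shared, a group holding a five-membered non-aromatic ring in place of a group holding a five-membered aromatic ring gives an 8.7-fold lower number from compound 1 to compound 4 (0.94 log units; beyond the scatter), a single-place comparison that the earlier compounds could not offer and one that points to the ring-bearing group, not the chain, as the place where the number moves. Nothing measured here explains either step.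

The compounds shown leave open whether a longer chain, or a chain ending in an amine or a carboxylic acid in place of the alkene, would keep the number level. They also leave open whether the chain change would behave the same way with the aromatic ring group present.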